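Hydroxy Joins the Pyridine Ring of Compound 1

The compounds below may be only part of what the source reports. "The series", "measured", "known", "first", "only" and "open" are said of these compounds alone.

Three compounds share one core and differ only in the pyridine ring attached to it. Compound 1 `CCCN(CCC)c1cc(C)nc2c(-c3ccc(Cl)cn3)c(C)nn12` gives the highest of the three numbers in an assay on isolated protein for binding affinity to corticotropin-releasing factor receptor 1 (Homo sapiens) (on this read-out higher numbers stand for weaker inhibition and lower numbers for stronger inhibition), at 88 nM. Compound 2 `CCCN(CCC)c1cc(C)nc2c(-c3ncc(N)cc3C)c(C)nn12` gives 85 nM, and compound 3 `CCCN(CCC)c1cc(C)nc2c(-c3ncc(F)cc3C)c(C)nn12` gives 19 nM. The step from compound 1 to compound 4 `CCCN(CCC)c1cc(C)nc2c(-c3ncc(O)cc3C)c(C)nn12` brings (5-hydroxy-3-methylpyridin-2-yl in place of 5-chloropyridin-2-yl on an aromatic carbon). Within the data shown here, two measured steps bear on it: a 1.0-fold lower number from compound 1 to compound 2 (0.02 log units; within the scatter) and a 4.6-fold lower number from compound 1 to compound 3 (0.67 log units; beyond the scatter). The amino group, a hydrogen-bond donor like the hydroxy group, stayed within the scatter, while fluoro lowered the number modestly. Compound 4 is therefore expected to land between these outcomes, giving a 1.8-fold lower number from compound 1 to compound 4 (0.25 log units; within the scatter). The estimate for compound 4 is 50 nM, with a range from 20 nM to 130 nM.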

Compound 4, inhibition constant: 530 nM
Compound 4: middle estimate off by 11-fold (1.03 log units), on the low side; the measured number lies above the stated range.
By their numbers in this assay, from the lowest: compound 3; then compounds 2 and 1 (each within the scatter of the next); then compound 4.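

Swapping one group on this pyridine ring can matter far more than the earlier compounds suggested: hydroxy in place of fluoro gives the largest step shown (a 28-fold higher number from compound 3 to compound 4 (1.45 log units; beyond the scatter)). Hydroxy and amino are not interchangeable here either (a 6.2-fold higher number from compound 2 to compound 4 (0.79 log units; beyond the scatter)), and in this assay only hydroxy moves the number above that of the chloro compound (a 6.0-fold higher number from compound 1 to compound 4 (0.78 log units; beyond the scatter)). Nothing available explains this loss.

As far as these compounds go, how a methoxy group, as in 5-methoxy-3-methylpyridin-2-yl, would compare with hydroxy and fluoro remains open. Also open, from the compounds shown here alone, is what the ring methyl contributes, which 5-chloro-3-methylpyridin-2-yl could separate from the chloro-to-hydroxy change.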